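Methoxymethyl in place of propyl on a bromo-bearing core

The source may report more compounds than this note shows. Statements on the series, on what has been measured and on what is new or still open speak of the compounds shown alone.

Compounds measured in a functional assay for inhibition, with Homo sapiens as the target; on this read-out higher numbers stand for weaker inhibition and lower numbers for stronger inhibition:
compound 1 `Oc1nnc(Br)c2c(Br)nc(Br)n12` — 27000 nM
compound 2 `COCc1nc(Br)c2cnnc(O)n12` — > 48000 nM
compound 3 `CCCc1nc(Br)c2c(Br)nnc(O)n12` — 48000 nM

Compound 3 `CCCc1nc(Br)c2c(Br)nnc(O)n12` gives 48000 nM in this assay, the higher of the two numbers available, while compound 1 `Oc1nnc(Br)c2c(Br)nc(Br)n12` sits within the scatter of it at 27000 nM. For compound 2 `COCc1nc(Br)c2cnnc(O)n12` this assay reports only a limit, > 48000 nM, so no number is known there. Going by the values given here, the only measured step, a 1.8-fold higher number from compound 1 to compound 3 (0.25 log units; within the scatter), is within the scatter.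

Compound 4 `COCc1nc(Br)c2c(Br)nnc(O)n12` differs from compound 3 by methoxy in place of ethyl on a saturated chain carbon bound to an aromatic carbon. Among the compounds with values here, no measured step touches this change directly; compound 2 carries the same methoxymethyl chain but lacks one bromo, and for it only a limit is recorded (the limit of > 48000 nM in this assay, at which 1 of the 3 values shown sits). Within the data shown here, on the single measured step, which was within the scatter, the expectation for compound 4 is a step of about a 1.1-fold lower number from compound 3 to compound 4 (0.03 log units; within the scatter), that is, no change beyond the scatter, with a real chance that only a limit is reported. Compound 4 is therefore estimated at 45000 nM, between 15000 nM and 130000 nM.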

Compound 4, half-maximal inhibitory concentration: > 48000 nM
Compound 4: no number, only a limit (the forecaster's own chance of this, stated with the estimate: 40%); at least 1.0-fold (0.02 log units) between middle value and limit.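

In this assay, methoxy in place of ethyl on a saturated chain carbon bound to an aromatic carbon gives a number no lower from compound 3 to compound 4 (the limit leaves the size open). Compound 4 has a limit rather than a number, so the methoxymethyl chain now gives only a limit with the bromo present as well as without it. Going by these compounds alone, the one readable step is an at least 1.7-fold higher number from compound 1 to compound 4 (0.24 log units; that floor lies within the scatter), and it establishes no change beyond the scatter. The steps to compound 4 from compound 2 and from compound 3 cannot be read in size because the values end at a limit: the limit of > 48000 nM in this assay, at which 2 of the 4 values shown sit.

From the compounds shown here alone, how much weaker compound 4 is than compound 3, if at all, therefore stays open. Also open, going by these compounds, is whether an amine, a carboxylic acid or a longer chain at this place would give a number within the range of the assay.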